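Working notes on a sulfamoyl-to-methoxy swap in the series

This account rests on a few compounds, and the source may have more. Where it says the series, first, only, none or still open, it means among the compounds named here.

Measured compounds in a functional assay on MDA-MB-231 cells (Homo sapiens) for antiproliferative activity, read by MTT assay, with a stated time of 48 h; on this read-out lower numbers stand for stronger inhibition and higher numbers for weaker inhibition:
- compound 1 `Cc1cnc(Nc2ccc(S(N)(=O)=O)cc2)nc1Nc1nc2ccccc2s1`: 16800 nM
- compound 2 `NS(=O)(=O)c1ccc(Nc2nccc(Nc3nc4ccccc4s3)n2)cc1`: 5000 nM
- compound 3 `Cc1cnc(Nc2ccc(S(N)(=O)=O)cc2)nc1Nc1nc2ccc(F)cc2s1`: 7580 nM

Compound 1 stands at the highest number of the three in this assay. Its nearest neighbour is compound 3, reached by a 2.2-fold lower number from compound 1 to compound 3 (0.35 log units; beyond the scatter) with fluoro in place of hydrogen on an aromatic carbon. The furthest is compound 2, reached by a 3.4-fold lower number from compound 1 to compound 2 (0.53 log units; beyond the scatter) with hydrogen in place of methyl on an aromatic carbon.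

Compound 4 `COc1ccc(Nc2ncc(C)c(Nc3nc4ccccc4s3)n2)cc1` is not yet measured. It differs from compound 1 as follows: methoxy in place of sulfamoyl on an aromatic carbon. Neither measured step touches this part of the shared core; both change other positions, and both lowered the number only modestly. Among the compounds with values here, no step bears directly on replacing sulfamoyl with methoxy, so the expectation for compound 4 rests on compound 1 alone and carries a wide range. Compound 4 is therefore expected to land near compound 1, with a 1.1-fold lower number from compound 1 to compound 4 (0.05 log units; within the scatter) as the estimated step and no confident direction. The estimate for compound 4 in this assay is 15000 nM, with a range from 4000 nM to 50000 nM.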

Compound 4, half-maximal inhibitory concentration: > 50000 nM
Compound 4: no number, only a limit; the forecaster's own chance of this, stated with the estimate: 15%; at least 3.3-fold (0.52 log units) between middle value and limit.
By their numbers in this assay, from the lowest: compounds 2 and 3 (each within the scatter of the next); then compound 1. At a limit, above all of these: compound 4.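

In this assay compound 4 gives > 50000 nM, which is a limit of the assay and not a number. Methoxy in place of sulfamoyl, on an aromatic carbon para to a large group, gives an at least 2.9-fold higher number from compound 1 to compound 4 (0.47 log units; beyond the scatter), so this is the only position among the compounds shown where a change raises the number, whereas both changes elsewhere on the shared core lowered it. Every compound that keeps sulfamoyl here gives a measured number, the one compound carrying methoxy does not, and the step is therefore bounded on one side only: the limit of > 50000 nM in this assay, at which 1 of the 4 values shown sits.

Within the data shown here, the single swap cannot separate the loss of sulfamoyl from the arrival of methoxy, and a reading at this position with an amine, a carboxylic acid or a methylsulfonyl group would help to tell these apart. Also open, going by these compounds, is whether the lower numbers that came with hydrogen in place of methyl and with fluoro in place of hydrogen carry over to a compound with methoxy at this position, as both of those changes are seen here only with sulfamoyl in place.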